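A Pyrazole in Place of Isopropyl on the Amide Nitrogen

A few compounds are considered here, and "the series" means these few. Any claim that something is new, unique, unknown or untested is made for them only; others in the source may bear on it.

Of the compounds shown here, three sharing one core have been measured in an assay on HEK293 cells for agonist activity at transient receptor potential cation channel subfamily M member 8 (Homo sapiens), read by fluorescence and calcium flux, with a stated time of 15 min; a lower number here means that less compound is needed, a higher number that more compound is needed for the effect. Compound 1 `CCN(Cc1cccs1)C(=O)COc1ccc(C(C)C)cc1` gives 397 nM. Compound 2 `Cc1ccc(OCC(=O)N(Cc2cccs2)C(C)C)cc1` gives 70 nM, and compound 3 `CCN(Cc1cccs1)C(=O)COc1ccc2c(c1)COC2` gives 61 nM. Of these three numbers, compound 2 holds the second highest place. Its nearest neighbour is compound 3, whose value sits within the usual scatter of that of compound 2, so the two cannot be separated on this evidence. Compound 1 lies furthest from compound 2, and that gap is beyond the scatter, so compound 1 needs more material for the effect than compound 2 does.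

The step in question leads from compound 2 to compound 4 `Cc1ccc(OCC(=O)N(Cc2cccs2)c2c[nH]nc2C)cc1`, which has not yet been measured in this assay. The change is 3-methyl-1H-pyrazol-4-yl in place of isopropyl on an amide-type nitrogen. Among the compounds with values here, no measured pair differs in only one place, and none of the measured compounds carries a ring on the amide-type nitrogen, so nothing measured speaks directly to this change. The account therefore expects a step in this assay from compound 2 to compound 4 of a 4.3-fold higher number from compound 2 to compound 4 (0.63 log units; beyond the scatter), toward a higher number and beyond the scatter. The estimate for compound 4 in this assay is 300 nM, with a range from 80 nM to 1500 nM.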

Compound 4, half-maximal effective concentration: 0.4 nM
The estimate for compound 4 lay 750-fold (2.88 log units) above the measured number; the whole stated range lies above it.
By their numbers in this assay, from the lowest: compound 4; then compounds 3 and 2 (each within the scatter of the next); then compound 1.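

In this assay, the group on the amide-type nitrogen, whose other neighbours are the carbonyl carbon and a saturated chain carbon, proves to have a very large bearing on the number: 3-methyl-1H-pyrazol-4-yl in place of isopropyl gives a 180-fold lower number from compound 2 to compound 4 (2.24 log units; beyond the scatter) and so shows how far the number can move at this one place. Within the data shown here, none of the earlier compounds carried a ring on this nitrogen, so they gave no sign that a five-membered aromatic ring with 2 hetero atoms could stand here, still less with so low a number. No evidence is available on why the entering group has this effect.

An unsubstituted pyrazole or a phenyl ring on this nitrogen lies outside the compounds shown, which leaves open whether the step belongs to the ring itself, to its two nitrogens or to its methyl group. The compounds shown also leave open whether 3-methyl-1H-pyrazol-4-yl would give a step of similar size with the other aryl ether portions seen in compound 1 and compound 3.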